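A few compounds are considered here, and "the series" means these few. Any claim that something is new, unique, unknown or untested is made for them only; others in the source may bear on it.

In a functional assay on HL-60 cells (Homo sapiens) for cytotoxicity, read by CellTiter-Blue, with a stated time of 48 h (on this read-out higher numbers stand for weaker inhibition and lower numbers for stronger inhibition), three compounds have been measured. Compound 1 `C#CCOC(=O)CC1C(C(=O)OCC)=C(N)Oc2ccc(-c3cc(OC)cc(OC)c3)cc21` gives 4700 nM, compound 2 `C#CCOC(=O)CC1C(C(=O)OCC)=C(N)Oc2ccc(-c3cccc(N)c3)cc21` gives 3400 nM and compound 3 `C#CCOC(=O)CC1C(C(=O)OCC#C)=C(N)Oc2ccc(-c3cccc(N)c3)cc21` gives 1240 nM. Compound 2 thus belongs with compound 1 at the upper end of these three numbers, while compound 3 stands lower.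

The next compound to be tested in this assay is compound 4 `C#CCOC(=O)CC1C(C(=O)OCC)=C(N)Oc2ccc(-c3ccc(N)cc3)cc21`. It has the same atoms as compound 2, joined differently: 4-aminophenyl in place of 3-aminophenyl on an aromatic carbon.

Going by the values given here, no measured pair moves the amino group around its ring, so the data give no direction for this change. The closest evidence is the replacement of the whole aryl group on that aromatic carbon, which gave a 1.4-fold lower number from compound 1 to compound 2 (0.14 log units; within the scatter). The other measured step, a 2.7-fold lower number from compound 2 to compound 3 (0.44 log units; beyond the scatter), comes from a change in an ester chain and leaves the aminophenyl group untouched, so it bears on this question only weakly.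

A shift of the amino group alone is therefore not expected to move the number beyond the scatter in either direction. The expected change is a 1.1-fold lower number from compound 2 to compound 4 (0.03 log units; within the scatter). The estimate for compound 4 is 3200 nM, with an expected range from 1400 nM to 7000 nM.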

Compound 4, half-maximal inhibitory concentration: 10500 nM
Estimate against measurement, compound 4: 3.3-fold (0.52 log units) below; the measured number lies above the stated range.
By their numbers in this assay, from the lowest: compound 3; then compounds 2 and 1 (each within the scatter of the next); then compound 4.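

In this assay the position of the amino group on the aryl ring turns out to matter: 4-aminophenyl in place of 3-aminophenyl gives a 3.1-fold higher number from compound 2 to compound 4 (0.49 log units; beyond the scatter) even though the two groups have the same atoms and the same counts of donors and acceptors, leaving only the position of the amino group to separate them. The earlier pair had suggested that this aromatic carbon was indifferent to the choice of aryl group, since 3,5-dimethoxyphenyl and 3-aminophenyl stayed within the scatter of each other, but 4-aminophenyl in place of 3,5-dimethoxyphenyl gives a 2.2-fold higher number from compound 1 to compound 4 (0.35 log units; beyond the scatter) and so separates from both. Nothing available here accounts for this dependence on the position of the amino group.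

On these data alone, it remains open whether a hydroxyl or an acetamido group in place of the amino group would show the same dependence on position. Also open, as far as these compounds go, is whether the ethynyl change in the ester chain would have the same size with 4-aminophenyl as with 3-aminophenyl.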